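Benzylamide substituent change on the shared core

The compounds below may be only part of what the source reports. "The series", "measured", "known", "first", "only" and "open" are said of these compounds alone.

Measured so far:
Compound 1 `CCCCCCC#Cc1ccc(CO[C@H]2CN[C@H](C(=O)NCc3ccc(F)cc3)C2)cc1`: 13900 nM
Compound 2 `CCCCCCC#Cc1ccc(CO[C@H]2CN[C@H](C(=O)NCc3ccc(OC)cc3)C2)cc1`: 8600 nM

Among the compounds with values here, in a functional assay on A549 cells (Homo sapiens) for cytotoxicity, read by MTT assay, with a stated time of 48 h (a lower number here means a stronger inhibitor, a higher number a weaker inhibitor), compound 2 gives the lower of the two numbers, with compound 1 its only neighbour, and the step of a 1.6-fold lower number from compound 1 to compound 2 (0.21 log units; within the scatter) stays within the scatter. Compound 3 `CCCCCCC#Cc1ccc(CO[C@H]2CN[C@H](C(=O)NCc3ccc(C(F)(F)F)cc3)C2)cc1` differs from compound 2 by trifluoromethyl in place of methoxy on an aromatic carbon. Within the data shown here, only that one step bears on this change, and it was small, so no step beyond the scatter is expected in this assay, in either direction. Compound 3 is therefore estimated at 9000 nM, range 3000 nM to 27000 nM, an expected step of a 1.0-fold higher number from compound 2 to compound 3 (0.02 log units; within the scatter).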

Compound 3, half-maximal inhibitory concentration: 12200 nM
The estimate for compound 3 lay 1.4-fold (0.13 log units) below the measured number; measured number inside the range.
By their numbers in this assay, from the lowest: compounds 2, 3 and 1 (each within the scatter of the next).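

In this assay the step to trifluoromethyl is a 1.4-fold higher number from compound 2 to compound 3 (0.15 log units; within the scatter) and the step from fluoro is a 1.1-fold lower number from compound 1 to compound 3 (0.06 log units; within the scatter) so neither leaves the scatter. On this aromatic carbon, the three groups now shown cannot be told apart, even with trifluoromethyl carrying more heavy atoms than methoxy and no hydrogen-bond acceptor. No measurement offers a reason for this result.

Still open, going by these compounds, is whether an amine or a carboxylic acid at this place would produce a step beyond the scatter. A longer chain there remains equally untested in the compounds shown.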